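Replacing a ring group on compound 3

The source may report more compounds than this note shows. Statements on the series, on what has been measured and on what is new or still open speak of the compounds shown alone.

In a functional assay on COR-L23 cells (Homo sapiens) for antiproliferative activity, read by CellTiter-Glo, with a stated time of 72 h (a higher number here means a weaker inhibitor, a lower number a stronger inhibitor), compound 3 `C[C@@H](c1ccc(NC(=O)N2CC(c3cccnc3)C2)cc1)N1Cc2ccccc2C1=O` gives 8 nM, within the scatter of compound 2 `O=C(Nc1ccc(CN2Cc3ccccc3C2=O)cc1)N1CC(c2cccnc2)C1` at 9.9 nM, while compound 1 `O=C(Nc1ccc(CN2C(=O)c3ccccc3C2=O)cc1)[C@H]1C[C@@H]1c1cccnc1` gives a clearly higher 35 nM. Compound 4 `C[C@H](NC(=O)c1ncccn1)c1ccc(NC(=O)N2CC(c3cccnc3)C2)cc1` makes one change to compound 3: a group of 9 heavy atoms (5 carbon, 3 nitrogen, 1 oxygen; one six-membered aromatic ring with 2 hetero atoms) in place of a group of 10 heavy atoms (8 carbon, 1 nitrogen, 1 oxygen; one five-membered non-aromatic ring with 1 hetero atom, one six-membered aromatic ring of carbon only), on a saturated chain carbon bound to an aromatic carbon and a saturated chain carbon. The entering group is ((pyrimidin-2-yl)carbonyl)amino. For the measured compounds named here, the only measured single change, a 1.2-fold lower number from compound 2 to compound 3 (0.09 log units; within the scatter), added a methyl and did not swap this group, so it offers little guidance. With compound 3 at 8 nM already low among these numbers, a modest rise in this assay is expected rather than a further fall. The estimated change is a 2.5-fold higher number from compound 3 to compound 4 (0.40 log units; beyond the scatter). For compound 4 the expected value is 20 nM, within an estimated range of 6 nM to 70 nM.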

Compound 4, half-maximal inhibitory concentration: 130 nM
The estimate for compound 4 lay 6.5-fold (0.81 log units) below the measured number, and the stated range ends below it.
By their numbers in this assay, from the lowest: compounds 3 and 2 (each within the scatter of the next); then compound 1; then compound 4.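

On the saturated chain carbon bound to an aromatic carbon and a saturated chain carbon, the group strongly affects the result. In this assay, ((pyrimidin-2-yl)carbonyl)amino entering in place of the group with a five-membered non-aromatic ring gives a 16-fold higher number from compound 3 to compound 4 (1.21 log units; beyond the scatter), whereas adding a methyl on that carbon gave only a 1.2-fold lower number from compound 2 to compound 3 (0.09 log units; within the scatter). No measurement shown explains the size of this rise. The compounds shown leave open whether the pyrimidine ring or the amide linking it accounts for the rise; a benzoylamino group on this carbon would help separate the two.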